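Replacing the benzyloxy aryl in an antiproliferative series

A few compounds are considered here, and "the series" means these few. Any claim that something is new, unique, unknown or untested is made for them only; others in the source may bear on it.

Compound 1 `Cc1ccccc1COc1ccc(-c2cc(CN3CCN(Cc4ccc(C(F)(F)F)cc4)CC3)no2)cc1` gives 3700 nM in a functional assay on MCF7 cells (Homo sapiens) for antiproliferative activity, read by sulforhodamine B assay, with a stated time of 72 h (on this read-out higher numbers stand for weaker inhibition and lower numbers for stronger inhibition), while compound 2 `N#Cc1cccc(COc2ccc(-c3cc(CN4CCN(Cc5ccc(C(F)(F)F)cc5)CC4)no3)cc2)c1` gives 800 nM, the lowest of the two numbers; the change was a 4.6-fold lower number from compound 1 to compound 2 (0.67 log units; beyond the scatter). Compound 3 `COc1cc(COc2ccc(-c3cc(CN4CCN(Cc5ccc(C(F)(F)F)cc5)CC4)no3)cc2)cc(OC)c1` carries 3,5-dimethoxyphenyl in place of 3-cyanophenyl on a saturated chain carbon bound to an oxygen on an aromatic ring. Among the compounds with values here, the only measured step that bears on this place is that from compound 1 to compound 2, which was modest, so the new aryl is expected to move the number by a similar or smaller amount, direction uncertain. The step is therefore estimated as a 1.9-fold higher number from compound 2 to compound 3 (0.27 log units; within the scatter). Compound 3 is expected to give about 1500 nM, within 400 nM to 6000 nM.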

Compound 3, half-maximal inhibitory concentration: 100 nM
Beside the measured number, compound 3's estimate is 15-fold (1.18 log units) above it; the whole stated range lies above it.
By their numbers in this assay, from the lowest: compound 3; then compound 2; then compound 1.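

In this assay, this position on a saturated chain carbon bound to an oxygen on an aromatic ring proves more responsive than the earlier pair could show: 3,5-dimethoxyphenyl gives an 8.0-fold lower number from compound 2 to compound 3 (0.90 log units; beyond the scatter) and a 37-fold lower number from compound 1 to compound 3 (1.57 log units; beyond the scatter). Its two methoxy groups thus outperform both the nitrile and the methyl-bearing aryl groups. Nothing available explains this gain.

The compounds shown leave open whether both methoxy groups are needed, since a phenyl ring with a single methoxy group does not appear among them. On these data alone, how an amine on this ring would compare also remains open.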